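Lengthening the Hydroxamic Acid Chain by One Carbon

The source may hold more compounds than are shown below. What is called first, only, known or untested is meant among the compounds shown, and "the series" means these compounds.

Compound 1 `COc1cc2ncnc(Nc3cccc(Cl)c3)c2cc1OCCC(=O)NO` gives > 100000 nM (a limit of the assay, not a number)
Compound 2 `COc1cc2ncnc(Nc3cc(Cl)ccc3Cl)c2cc1OCCCCC(=O)NO` gives 13700 nM (a measured number)
Compound 3 `COc1cc2ncnc(Nc3ccc(Cl)cc3Cl)c2cc1OCCCC(=O)NO` gives 56800 nM (a measured number)

These results come from a functional assay on MCF7 cells (Homo sapiens) for antiproliferative activity, read by MTT assay, with a stated time of 48 h (on this read-out higher numbers stand for weaker inhibition and lower numbers for stronger inhibition), and share one core. Compound 2 stands lowest of the two real numbers, which makes it a stronger inhibitor than compound 3 in this assay on these values. The entry for compound 1 is a limit.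

Compound 1 carries a 2-(hydroxycarbamoyl)ethyl chain, compound 3 a 3-(hydroxycarbamoyl)propyl chain and compound 2 a 4-(hydroxycarbamoyl)butyl chain. Within the data shown here, these compounds also differ elsewhere, so no single-change step between them has been measured.

Compound 4 `COc1cc2ncnc(Nc3cc(Cl)ccc3Cl)c2cc1OCCCCCC(=O)NO` matches compound 2 except that (hydroxycarbamoyl)methyl stands in place of hydroxycarbamoyl on a saturated chain carbon, four bonds along the chain from an oxygen on an aromatic ring ((hydroxycarbamoyl)methyl in place of hydroxycarbamoyl on a saturated chain carbon, four bonds along the chain from an oxygen on an aromatic ring).

The longer chain of compound 2 at 13700 nM goes with a lower number than the shorter chain of compound 3 at 56800 nM and this weak hint points to a further modest fall. The expected size of the step is a 2.1-fold lower number from compound 2 to compound 4 (0.32 log units; beyond the scatter) and it is a cautious guess toward stronger inhibition. For compound 4 the estimated value is 6500 nM (expected range 2000 nM to 20000 nM).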

Compound 4, half-maximal inhibitory concentration: 4000 nM
Beside the measured number, compound 4's estimate is 1.6-fold (0.21 log units) above it, within the range that was stated.
By their numbers in this assay, from the lowest: compound 4; then compound 2; then compound 3. At a limit, above all of these: compound 1.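

In this assay, replacing hydroxycarbamoyl with (hydroxycarbamoyl)methyl on a saturated chain carbon, four bonds along the chain from an oxygen on an aromatic ring, gives a 3.4-fold lower number from compound 2 to compound 4 (0.53 log units; beyond the scatter), a modest step but one beyond the scatter. Among these compounds, this is the first comparison here in which only the chain differs, so a change in the number can be tied to this one-carbon extension alone, whereas the earlier compounds also differed elsewhere. Compound 1 cannot serve as a numerical starting point for the chain series, since it offers only a limit: the limit of > 100000 nM in this assay, at which 1 of the 4 values shown sits.

As far as these compounds go, a single step does not make a trend, so it remains open whether a longer chain than that of compound 4 would lower the number further, leave it unchanged or raise it. Also open, from the compounds shown here alone, are whether the same extension has a similar effect with the chlorine pattern of compound 1 or compound 3, and whether a carboxylic acid in place of the hydroxycarbamoyl would keep any of this activity.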